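The source may hold more compounds than are shown below. What is called first, only, known or untested is meant among the compounds shown, and "the series" means these compounds.

Compound 1 `FC(F)(F)c1ccc(CSc2nc(Nc3ccccc3)c3ccccc3n2)cc1`: 26400 nM
Compound 2 `CCOc1ccccc1Nc1nc(SCc2ccc(C(F)(F)F)cc2)nc2ccccc12`: a limit, > 50000 nM

Of the compounds shown here, two have been measured in a functional assay on HGC-27 cells (Homo sapiens) for cytotoxicity, read by MTT assay, with a stated time of 72 h; on this read-out higher numbers stand for weaker inhibition and lower numbers for stronger inhibition. Compound 1 gives 26400 nM. Compound 2 reaches only the limit of > 50000 nM, so no number is known for it. Among the values shown, compound 1 therefore holds the only actual number, while the other value is a limit (the limit of > 50000 nM in this assay, at which 1 of the 2 values shown sits). The step from compound 1 to compound 2 is an at least 1.8-fold higher number from compound 1 to compound 2 (0.27 log units; that floor lies within the scatter), with ethoxy in place of hydrogen on an aromatic carbon.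

Compound 3 `Cc1ccccc1Nc1nc(SCc2ccc(C(F)(F)F)cc2)nc2ccccc12` is not yet measured. It differs from compound 1 by methyl in place of hydrogen on an aromatic carbon. The measured step from compound 1 to compound 2 is the only one that bears on this change, since it alters the same aromatic position with a different group, and its size was at least an at least 1.8-fold higher number from compound 1 to compound 2 (0.27 log units; that floor lies within the scatter). A step in the same direction, though perhaps not beyond the scatter, is expected, a 1.5-fold higher number from compound 1 to compound 3 (0.18 log units; within the scatter). Compound 3 is estimated at 40000 nM, with a range from 15000 nM to 100000 nM.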

Compound 3, half-maximal inhibitory concentration: 27500 nM
For compound 3 the middle estimate is 1.5-fold (0.16 log units) above the measured one; the range from low to high includes it.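

Methyl in place of hydrogen gives a 1.0-fold higher number from compound 1 to compound 3 (0.02 log units; within the scatter) in this assay, so at this position, ortho to a large group, the added methyl brings no change that can be told from scatter. Methyl in place of ethoxy gives an at least 1.8-fold lower number from compound 2 to compound 3 (0.25 log units; that floor lies within the scatter), and since that floor also lies within the scatter, this step does not yet separate the two groups. Going by these compounds, the true size of that step stays unknown because compound 2 has only a limit and not a number: the limit of > 50000 nM in this assay, at which 1 of the 3 values shown sits.

On these data alone, whether ethoxy really differs from methyl or hydrogen here remains open. As far as these compounds go, it is also open whether an amine, a carboxylic acid or a longer chain such as butoxy at this position would move the number beyond the scatter.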